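This account rests on a few compounds, and the source may have more. Where it says the series, first, only, none or still open, it means among the compounds named here.

Compound 1 `O=C(COc1ccc(C(=O)/C=C/c2ccc(Cl)cc2Cl)cc1)N[C@H]1CCOC1=O` is the one chalcone amide in this set with a number: in a functional assay on MGC-803 cells (Homo sapiens) for antiproliferative activity, read by MTT assay, with a stated time of 72 h (a higher number here means a weaker inhibitor, a lower number a stronger inhibitor), compound 1 gives 26500 nM. Compound 2 `CCCCCCCCCCSC(=S)N[C@H]1CCOC1=O` yields no number here, only the assay limit, > 64000 nM for compound 2; this is the limit of > 64000 nM in this assay, at which 1 of the 2 values shown sits. Compound 3 `O=C(COc1ccc(C(=O)/C=C/c2ccc(Br)cc2)cc1)N[C@H]1CCOC1=O` carries the change (4-bromophenyl in place of 2,4-dichlorophenyl on a double-bonded chain carbon bound to a double-bonded chain carbon). Within the data shown here, no measured step lets the effect of this change be sized, so the expected step from compound 1 to compound 3, a 1.2-fold higher number from compound 1 to compound 3 (0.08 log units; within the scatter), is set within the scatter, with a slight lean toward weaker. Compound 3 is thus estimated at 32000 nM, with a range of 11000 nM to 64000 nM.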

Compound 3, half-maximal inhibitory concentration: 51000 nM
Compound 3: middle estimate off by 1.6-fold (0.20 log units), on the low side, within the range that was stated.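

Among these compounds, the step in this assay is a 1.9-fold higher number from compound 1 to compound 3 (0.28 log units; within the scatter), the first measured step, and it is for 4-bromophenyl in place of 2,4-dichlorophenyl on a double-bonded chain carbon bound to a double-bonded chain carbon. At this position, the two groups cannot be told apart in this read-out. Nothing available bears on the reason for this result.

As far as these compounds go, it remains open whether an amine or a carboxylic acid on this phenyl ring, in place of the halogens, would move the value beyond the scatter.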